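The compounds below may be only part of what the source reports. "The series", "measured", "known", "first", "only" and "open" are said of these compounds alone.

Measured so far:
compound 1, `Nc1[nH]c(C(=O)c2ccccc2)c(-c2ccc(Cl)cc2Cl)c1C(=O)c1ccccc1` — > 100000 nM
compound 2, `Nc1[nH]c(C(=O)c2ccccc2)c(-c2ccncc2)c1C(=O)c1cccc(Cl)c1` — > 100000 nM
compound 3, `Nc1[nH]c(C(=O)c2ccccc2)c(-c2c(F)cccc2F)c1C(=O)c1ccc(Cl)c(Cl)c1` — > 100000 nM

Of the compounds shown here, three on the shared core have been tested in an assay for inhibition of Polyunsaturated fatty acid lipoxygenase ALOX15 (Homo sapiens), with a stated time of 10 min (a lower number here means a stronger inhibitor, a higher number a weaker inhibitor), and none has given a number. Compound 1 reaches only a limit, > 100000 nM. Compound 2 also reaches only a limit, > 100000 nM. Compound 3 likewise reaches only a limit, > 100000 nM. Compound 2 therefore stands where every measured member stands: at the limit of > 100000 nM in this assay, at which 3 of the 3 values shown sit. Nothing on the numbers shown separates compound 2 from compound 1 or compound 3, and no step between measured compounds can be drawn.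

Compound 4, `Nc1[nH]c(C(=O)c2ccccc2)c(-c2ccccc2Cl)c1C(=O)c1cccc(Cl)c1`, has not yet been measured in this assay. It differs from compound 2 in one place:

2-chlorophenyl in place of pyridin-4-yl on an aromatic carbon

No measured step exists to calibrate this change, so its size cannot be read from the shown data. With all three measured compounds sitting at the limit, nothing points to a gain in this assay, and the expected outcome is no movement beyond the scatter, with compound 4 most likely again reported only as a limit. The expected step is a step that the limit leaves unreadable from compound 2 to compound 4. For compound 4 the estimate is 150000 nM, ranging from 50000 nM to 500000 nM.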

Compound 4, half-maximal inhibitory concentration: > 100000 nM
Compound 4 was reported as a limit (the forecaster's own chance of this, stated with the estimate: 80%); the middle value is on the limit's open side.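

No step from compound 2 to compound 4 can be read, since both are reported only as limits: the limit of > 100000 nM in this assay, at which 4 of the 4 values shown sit.

The compounds shown leave open whether any change on the shared core gives a measurable number in this assay, and how the 2-chlorophenyl and pyridin-4-yl groups compare there.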